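Extending the hydroxymethyl arm of compound 3

The compounds below may be only part of what the source reports. "The series", "measured", "known", "first", "only" and "open" are said of these compounds alone.

Compound 3 `COc1ccc2c(c1)C(=O)OC(CO)C2` was tested in a functional assay on U-251 cells (Homo sapiens) for antiproliferative activity, read by sulforhodamine B assay, with a stated time of 48 h; on this read-out lower numbers stand for stronger inhibition of growth and higher numbers for weaker inhibition of growth. In this assay compound 3 gives only >= 250 ug/mL, which is a limit of the assay and not a number. Compound 2 `O=C1OC(CO)Cc2ccccc21` likewise gives the limit >= 250 ug/mL in this assay. Compound 1 `COc1ccc2cc(CO)oc(=O)c2c1` gives 167 ug/mL in this assay. The step that the two limits leave unreadable from compound 2 to compound 3 cannot be read because the limit of >= 250 ug/mL in this assay, at which 2 of the 3 values shown sit, covers both of its ends. Compound 4 `COc1ccc2c(c1)C(=O)OC(CCCO)C2` differs from compound 3 by 2-hydroxyethyl in place of hydroxy on a saturated chain carbon bound to a saturated ring carbon. Going by the values given here, no measured step touches this change, and the only measured step is unreadable, so no direction beyond the scatter can be expected in this assay. Compound 4 is therefore expected to give about 250 ug/mL, between 120 ug/mL and 500 ug/mL, an estimated step of a number no higher from compound 3 to compound 4 (the limit leaves the size open) of essentially no change, most likely ending again at the limit.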

Compound 4, concentration for 50% growth inhibition: 135 ug/mL
For compound 4 the middle estimate is 1.9-fold (0.27 log units) above the measured one; the measured number falls inside the stated range.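

Changing hydroxymethyl to 3-hydroxypropyl at this position gives a step that can be read in this assay: an at least 1.8-fold lower number from compound 3 to compound 4 (0.26 log units; that floor lies within the scatter). Compound 3 gives >= 250 ug/mL, which is a limit of the assay and not a number, so the true step could be larger than this floor. Compound 4 gives 135 ug/mL, a real number, so this longer arm brings growth inhibition within the measurable range.

Going by these compounds, whether chain length or the hydroxy at its end matters remains open. On these data alone, how a plain propyl chain, an amine or carboxylic acid at the chain end, or a still longer chain would read also stays unknown.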